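The source may report more compounds than this note shows. Statements on the series, on what has been measured and on what is new or still open speak of the compounds shown alone.

In a physicochemical assay for lipophilicity, in phosphate buffer, measured as octanol-water partition, at pH 7.4 (on this read-out higher numbers stand for higher lipophilicity and lower numbers for lower lipophilicity), compound 2 (`O=C(CN1CCN(c2ccncc2)CC1)Nc1nc2c(s1)CCCC2`) gives 2 as the lowest of three numbers, while compound 3 (`O=C(CN1CCN(c2ccc(F)cn2)CC1)Nc1nc2c(o1)CCCC2`) gives 2.7 and compound 1 (`O=C(CN1CCN(c2ccc(F)cc2)CC1)Nc1nc2c(o1)CCCC2`) gives 3 and so both stand beyond the scatter from compound 2. The change to compound 4 (`O=C(CN1CCN(c2cccnc2)CC1)Nc1nc2c(s1)CCCC2`) is pyridin-3-yl in place of pyridin-4-yl on an amine nitrogen in a ring and places pyridin-3-yl in place of pyridin-4-yl on an amine nitrogen in a ring. Among the compounds with values here, the only measured step at this place is a number 0.30 log units lower from compound 1 to compound 3 (within the scatter) and it exchanges 4-fluorophenyl for 5-fluoropyridin-2-yl, a different swap from the one at hand. Compound 2 also differs from compound 1 and compound 3 in the core, so the data cannot separate the contributions of core and pyridin-4-yl. Even so, a rise towards compound 3 at 2.7 is expected, since compound 2 at 2 may owe part of its gap to pyridin-4-yl. The expected change is estimated as a number 0.60 log units higher from compound 2 to compound 4 (beyond the scatter) and remains uncertain. The estimate for compound 4 is 2.6 with an expected range from 2.1 to 3.1 until the measurement is known.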

Compound 4, distribution coefficient: 3.3
Beside the measured number, compound 4's estimate is 0.70 log units below it; measured number outside the range, above it.
By their numbers in this assay, from the lowest: compound 2; then compounds 3, 1 and 4 (each within the scatter of the next, the first and the last beyond it).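

In this assay, the exchange of pyridin-4-yl for pyridin-3-yl on an amine nitrogen in a ring gives a large step (a number 1.30 log units higher from compound 2 to compound 4 (beyond the scatter)), although the two compounds have the same atoms, joined differently, and the same counts of hydrogen-bond donors and acceptors. Within the data shown here, this place on the molecule therefore responds strongly to which pyridinyl isomer it carries, something the only earlier step (a number 0.30 log units lower from compound 1 to compound 3 (within the scatter)), a different swap that stayed within the scatter, gave no sign of. Nothing available explains why these two isomers are so far apart.

On these data alone, whether a step of this size would also appear on the core of compound 1 remains open. So does where a pyridin-2-yl, a pyrimidin-5-yl or an unsubstituted phenyl at this place would fall in this assay.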